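Aryl variation on the amide nitrogen: next compound

The source may hold more compounds than are shown below. What is called first, only, known or untested is meant among the compounds shown, and "the series" means these compounds.

Measured so far in a functional assay on MDA-MB-231 cells (Homo sapiens) for antiproliferative activity, read by MTT assay, with a stated time of 72 h; a lower number here means a stronger inhibitor, a higher number a weaker inhibitor:
compound 1, `O=C(CCc1cccc2c1B(O)OC2)Nc1ccc(F)cc1`, gives 440 nM
compound 2, `O=C(CCc1cccc2c1B(O)OC2)Nc1cccc(I)c1`, gives 5300 nM

Compound 2 stands highest of the two numbers; its nearest neighbour is compound 1, and the gap is a 12-fold higher number from compound 1 to compound 2 (1.08 log units; beyond the scatter). The next compound, compound 3 `N#Cc1ccc(-c2cccc(NC(=O)CCc3cccc4c3B(O)OC4)c2)cc1`, differs from compound 2 in one place: 4-cyanophenyl in place of iodo on an aromatic carbon. Among the measured compounds shown here, only one measured step bears on this: a 12-fold higher number from compound 1 to compound 2 (1.08 log units; beyond the scatter), which also swapped the group carried by the aryl on the amide-type nitrogen and was large. A step of comparable size is therefore plausible for compound 3, but with a single step and a different group entering, the direction cannot be read from these two numbers alone. Compound 3 is estimated at 3000 nM, within a range of 600 nM to 15000 nM. The expected step is a 1.8-fold lower number from compound 2 to compound 3 (0.25 log units; within the scatter) in this assay.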

Compound 3, half-maximal inhibitory concentration: 380 nM
Compound 3: the middle estimate sits 7.9-fold (0.90 log units) above what was measured; the whole stated range lies above it.
By their numbers in this assay, from the lowest: compounds 3 and 1 (each within the scatter of the next); then compound 2.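

In this assay, a larger group at this aromatic carbon does not cost activity: the step is a 14-fold lower number from compound 2 to compound 3 (1.14 log units; beyond the scatter), with 4-cyanophenyl, 8 heavy atoms and one aromatic ring, replacing a single iodine atom. The high number of compound 2 therefore belongs to the iodo group and not to substitution at this carbon as such, and compound 3 and compound 1 lie within the scatter of each other despite their different aryl groups. No measurement shown here accounts for the size of this step.

From the compounds shown here alone, whether the nitrile or the added aromatic ring carries the step stays open; an unsubstituted phenyl, or a carboxylic acid in place of the nitrile, would separate the two. Going by these compounds, how an amine or a morpholine at this carbon would read also remains open.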